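The source may hold more compounds than are shown below. What is called first, only, known or untested is meant among the compounds shown, and "the series" means these compounds.

Compound 1 `OC[C@H]1O[C@@H](n2cnc3c(NCc4ccc(Cl)cc4Cl)ncnc32)[C@H](O)[C@@H]1O` was tested in a functional assay on HL-60 cells (Homo sapiens) for antiproliferative activity, with a stated time of 72 h (a higher number here means a weaker inhibitor, a lower number a stronger inhibitor), where compound 1 gives 96300 nM. Within the data shown here, that is the only number available: a second compound, compound 2 `COc1cc(CNc2ncnc3c2ncn3[C@@H]2O[C@H](CO)[C@@H](O)[C@H]2O)cc(OC)c1O`, was prepared as well, but in this assay compound 2 is recorded as "not determined" (no result reported), so compound 1 stands alone as the sole measured point and there is no step between measured compounds to learn from.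

Compound 3 `Cc1ccc(O)c(CNc2ncnc3c2ncn3[C@@H]2O[C@H](CO)[C@@H](O)[C@H]2O)c1` shares the core of compound 1 and differs from it in a single place (2-hydroxy-5-methylphenyl in place of 2,4-dichlorophenyl on a saturated chain carbon bound to a nitrogen on an aromatic ring). The group that leaves carries no hydrogen-bond donor or acceptor, while the 2-hydroxy-5-methylphenyl group that enters brings one of each. Among the measured compounds shown here, with no comparable pair measured, there is nothing in the data to say whether such an exchange helps or hurts.

Given the weak starting point of compound 1, the step is expected to be small, within the usual scatter or at most a slight weakening, as a 1.1-fold higher number from compound 1 to compound 3 (0.06 log units; within the scatter) expresses. Compound 3 is therefore estimated to give about 110000 nM in this assay, with a likely range from 35000 nM to 350000 nM.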

Compound 3, half-maximal inhibitory concentration: 15000 nM
Compound 3: middle estimate off by 7.3-fold (0.87 log units), on the high side; the measured number lies below the stated range.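

In this assay, exchanging 2,4-dichlorophenyl for 2-hydroxy-5-methylphenyl on a saturated chain carbon bound to a nitrogen on an aromatic ring gives a step beyond the usual scatter (a 6.4-fold lower number from compound 1 to compound 3 (0.81 log units; beyond the scatter)), which a single measured compound could not have shown. This position therefore responds to what the aromatic ring carries, even though both groups hold the same number of heavy atoms and the shared core stays the same. Nothing measured here explains why the number fell, so the step remains an observation without a cause.

Several things change at once in this exchange: both chlorines leave, while a hydroxyl and a methyl enter, so the hydroxyl alone, the methyl alone or the loss of the chlorines could each account for the step. Also open, from the compounds shown here alone, is how the same assay, this assay, would respond to a ring bearing an amine or a carboxylic acid, or to a longer chain in place of the single saturated chain carbon.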